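Moving from cycloheptyl to cyclohexylmethyl at the benzylic carbon

This account rests on a few compounds, and the source may have more. Where it says the series, first, only, none or still open, it means among the compounds named here.

Of the compounds shown here, two have been measured in a functional assay for inhibition of Polyunsaturated fatty acid 5-lipoxygenase (Homo sapiens); on this read-out higher numbers stand for weaker inhibition and lower numbers for stronger inhibition. Compound 1 `C=CCC(O/N=C(\C)C(=O)O)c1ccc(OCc2ccc3ccccc3n2)cc1` carries an allyl group on the saturated chain carbon bound to an aromatic carbon and an oxygen, and in this assay compound 1 gives 142 nM. Compound 2 `C/C(=N\OC(c1ccc(OCc2ccc3ccccc3n2)cc1)C1CCCCCC1)C(=O)O` carries a cycloheptyl group at the same place, and in this assay compound 2 gives 13 nM. Going by the values given here, the step of an 11-fold lower number from compound 1 to compound 2 (1.04 log units; beyond the scatter) is the only measured change at this position, and it is large, so compound 2 stands as the lower of the two numbers, with compound 1 as its only neighbour.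

Compound 3 `C/C(=N\OC(CC1CCCCC1)c1ccc(OCc2ccc3ccccc3n2)cc1)C(=O)O` differs from compound 2 by cyclohexylmethyl in place of cycloheptyl on a saturated chain carbon bound to an aromatic carbon and an oxygen. Among the compounds with values here, no measured step covers exactly this exchange; the one step that bears on it, from compound 1 to compound 2, shows that a sizeable saturated group at this carbon is tied to a far lower number than allyl. Since cyclohexylmethyl keeps the same count of carbons in a saturated, non-aromatic form, compound 3 is expected to stay near compound 2, with a step of about a 1.5-fold higher number from compound 2 to compound 3 (0.19 log units; within the scatter), and its estimated value in this assay is 20 nM, within 6 nM to 70 nM.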

Compound 3, half-maximal inhibitory concentration: 29 nM
For compound 3 the middle estimate is 1.5-fold (0.16 log units) below the measured one; measured number inside the range.
By their numbers in this assay, from the lowest: compound 2; then compound 3; then compound 1.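

In this assay, the exchange of two groups built from the same atoms does not leave the number unchanged: a 2.2-fold higher number from compound 2 to compound 3 (0.35 log units; beyond the scatter), so the saturated chain carbon bound to an aromatic carbon and an oxygen responds to how those atoms are arranged, and not only to which atoms are present. Cyclohexylmethyl nevertheless retains much of the advantage seen with cycloheptyl, with a 4.9-fold lower number from compound 1 to compound 3 (0.69 log units; beyond the scatter), so a lower number than with allyl is not confined to a single group and holds for both ring-bearing groups, with cycloheptyl giving the lowest number of the three. No measurement presented here accounts for either step.

From the compounds shown here alone, it remains open whether a saturated ring is needed at all at this carbon, or whether a longer open chain such as heptyl would give a number as low as cycloheptyl does. Going by these compounds, the outcome with an aromatic group such as benzyl, or with an amine such as piperidinyl, at this same carbon also remains open, so the limits of what this position tolerates are still undefined.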